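A Methyl on a Saturated Ring Carbon: Expected Step

The compounds below may be only part of what the source reports. "The series", "measured", "known", "first", "only" and "open" are said of these compounds alone.

Compound 1 `COc1cc2c(Nc3ccc(C#N)cc3)ncnc2cc1OCCCN1CCCCC1` and compound 3 `COc1cc2c(Nc3ccccc3C#N)ncnc2cc1OCCCN1CCCCC1` share one core and differ only in the group on the nitrogen: 2-cyanophenyl in place of 4-cyanophenyl on a nitrogen on an aromatic ring. In a functional assay on MCF7 cells (Homo sapiens) for antiproliferative activity, read by MTT assay, with a stated time of 72 h (a lower number here means a stronger inhibitor, a higher number a weaker inhibitor), compound 1 gives 35100 nM and compound 3 gives 15200 nM, which is a 2.3-fold lower number from compound 1 to compound 3 (0.36 log units; beyond the scatter). Compound 2 `COc1cc2c(Nc3ccc(C#N)cc3)ncnc2cc1OCCCN1CCC(C)CC1` differs from compound 1 by methyl in place of hydrogen on a saturated ring carbon; in this assay compound 2 gives 43100 nM, and the step is a 1.2-fold higher number from compound 1 to compound 2 (0.09 log units; within the scatter). Compound 4 `COc1cc2c(Nc3ccccc3C#N)ncnc2cc1OCCCN1CCC(C)CC1` is not yet measured and carries the same change on compound 3: methyl in place of hydrogen on a saturated ring carbon. The two places are described in the same words. Because a 1.2-fold higher number from compound 1 to compound 2 (0.09 log units; within the scatter) lay within the scatter, the step from compound 3 to compound 4 is expected to be similar, about a 1.2-fold higher number from compound 3 to compound 4 (0.07 log units; within the scatter). Compound 4 is therefore estimated at 18000 nM in this assay, probably between 8000 nM and 40000 nM.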

Compound 4, half-maximal inhibitory concentration: 31900 nM
Beside the measured number, compound 4's estimate is 1.8-fold (0.25 log units) below it; measured number inside the range.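

In this assay, the methyl change gives a 2.1-fold higher number from compound 3 to compound 4 (0.32 log units; beyond the scatter), and the cyanophenyl change gives a 1.4-fold lower number from compound 2 to compound 4 (0.13 log units; within the scatter). The methyl change therefore behaves alike on both cores, as far as two steps can tell: the same change on two cores in this assay, a 1.2-fold higher number (0.09 log units; within the scatter) from compound 1 to compound 2 and a 2.1-fold higher number (0.32 log units; beyond the scatter) from compound 3 to compound 4, 1.7-fold (0.23 log units) apart, within the scatter of two such steps The cyanophenyl change agrees as well, though a single pair of steps shows agreement only within these compounds, not that either change would carry over to other cores: the same change on two cores in this assay, a 2.3-fold lower number (0.36 log units; beyond the scatter) from compound 1 to compound 3 and a 1.4-fold lower number (0.13 log units; within the scatter) from compound 2 to compound 4, 1.7-fold (0.23 log units) apart, within the scatter of two such steps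

The compounds shown leave open whether these steps hold when a morpholine or a dimethylamino group stands in place of the piperidin-1-yl. They also leave open what an ethyl or a hydroxyl in place of the methyl would do.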